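Para-methoxy analogue of an inactive pair

The source may hold more compounds than are shown below. What is called first, only, known or untested is meant among the compounds shown, and "the series" means these compounds.

Measured so far:
- compound 1 `O=c1[nH]nc2n(c1=O)CCN2c1ccccc1`: 0%
- compound 2 `O=c1[nH]nc2n(c1=O)CCN2c1cccc(Cl)c1`: 0%

Both measured compounds share one core and differ only in the aromatic substituent. In a functional assay on T47D cells (Homo sapiens) for cytotoxicity, with a stated time of 72 h, tested at 10 ug/mL (on this read-out higher numbers stand for a stronger effect at the one concentration tested and lower numbers for a weaker effect), compound 1 gives 0%, and compound 2 gives 0%. Among the compounds with values here, the single step available, no change at the digits printed from compound 1 to compound 2 (within the scatter), shows that putting chloro in place of hydrogen on an aromatic carbon leaves the read-out where it was. Compound 1 therefore stands level with compound 2, and neither shows any measurable effect at the tested concentration.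

Compound 3 `COc1ccc(N2CCn3c2n[nH]c(=O)c3=O)cc1` is the next member to be measured. Relative to compound 1 the change is methoxy in place of hydrogen on an aromatic carbon. Within the data shown here, the only step that bears on it is the chloro step from compound 1 to compound 2, which was flat within the scatter; no step with methoxy, and no step with a group carrying a hydrogen-bond acceptor, has been measured. With both known members at zero, no movement beyond the scatter is expected. Compound 3 is expected to give 2% in this assay, within 0% to 15%, so that the expected step is a number 2 percentage points higher from compound 1 to compound 3 (within the scatter).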

Compound 3, a percentage reported as inhibition, at one concentration (the size of the read-out at that concentration, not a potency): 7%
Compound 3: the middle estimate sits 5 percentage points below what was measured; the measured number falls inside the stated range.
By their numbers in this assay, from the lowest: compounds 1, 2 and 3 (each within the scatter of the next).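

Working from the shared core, methoxy in place of hydrogen on an aromatic carbon, para to a large group, gives in this assay a step of a number 7 percentage points higher from compound 1 to compound 3 (within the scatter) and so leaves the read-out without movement beyond the scatter. Within the data shown here, the earlier pair covered chloro alone, so this is the first step with a group carrying a hydrogen-bond acceptor, and on this evidence the position para to a large group tolerates methoxy without a clear gain at the one concentration tested. No measured evidence bears on the origin of this small read-out.

From the compounds shown here alone, it remains open whether an amine, a carboxylic acid or a longer alkoxy chain in the same place would lift the read-out beyond the scatter, or would leave it as flat as methoxy and chloro do. Going by these compounds, it is equally open whether changes on the shared core itself, rather than on the aromatic ring, would produce any clear effect in this assay at all.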